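Swapping an amine position in a chemokine receptor antagonist series

The source may hold more compounds than are shown below. What is called first, only, known or untested is meant among the compounds shown, and "the series" means these compounds.

Measured so far:
compound 1 `COc1cccc2c1c(NS(=O)(=O)c1ccc(Cl)s1)nn2Cc1cccc(CNC(=O)C2COC2)c1` — 20 nM
compound 2 `CN[C@H](C)C(=O)NCc1cccc(Cn2nc(NS(=O)(=O)c3ccc(Cl)s3)c3c(OC)cccc32)c1` — 15.9 nM

Both compounds were tested in a functional assay on CHO cells for antagonist activity at C-C chemokine receptor type 4 (Homo sapiens), read by GTPgammaS binding; a higher number here means a weaker inhibitor, a lower number a stronger inhibitor. Going by the values given here, compound 1 gives 20 nM and compound 2 gives 15.9 nM; the only measured step, a 1.3-fold lower number from compound 1 to compound 2 (0.10 log units; within the scatter), lies within the scatter, so neither compound can be called the stronger one on these two numbers.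

Compound 3 `COc1cccc2c1c(NS(=O)(=O)c1ccc(Cl)s1)nn2Cc1cccc(CNC(=O)C(C)(C)N)c1` has not yet been measured. It differs from compound 2 in one place: 1-amino-1-methylethyl in place of 1-(methylamino)ethyl on a carbonyl carbon. The same atoms are present, joined differently. Among the compounds with values here, no measured step touches exactly this change; the one step at this position, a 1.3-fold lower number from compound 1 to compound 2 (0.10 log units; within the scatter), shows that a different small group on the carbonyl carbon left the number within the scatter. On that slim basis, a step no larger than the scatter is expected, a 1.3-fold higher number from compound 2 to compound 3 (0.10 log units; within the scatter), and compound 3 is estimated at 20 nM, within a range from 8 nM to 50 nM.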

Compound 3, half-maximal inhibitory concentration: 15.9 nM
The estimate for compound 3 lay 1.3-fold (0.10 log units) above the measured number; the measured number falls inside the stated range.
By their numbers in this assay, from the lowest: compounds 2, 3 and 1 (each within the scatter of the next).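

Rearranging the same atoms from 1-(methylamino)ethyl to 1-amino-1-methylethyl on the carbonyl carbon, which also removes the defined stereocentre of compound 2, gives no change at the digits printed from compound 2 to compound 3 (within the scatter) in this assay. Among these compounds, then, neither where the nitrogen sits in this small group nor that stereocentre shows up in the number, and replacing oxetan-3-yl, which has no amine, gives a 1.3-fold lower number from compound 1 to compound 3 (0.10 log units; within the scatter). Nothing available explains why these three groups give numbers so close together.

From the compounds shown here alone, all three groups are small, so it remains open whether this position would stay as undemanding with a carboxylic acid or a longer chain ending in an amine on the carbonyl carbon. A group of that kind could show whether the position responds to any change at all.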